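Thiophene for pyridine on the enone carbon of the core

The compounds below may be only part of what the source reports. "The series", "measured", "known", "first", "only" and "open" are said of these compounds alone.

Measured compounds:
compound 1, `COc1ccc(C2=C(c3cccnc3)C(=O)N3CCCC3C2)cc1`, 79000 nM
compound 2, `COc1ccc(C2=C(c3ccncc3)C(=O)N3CCCC3C2)cc1`, 19000 nM

In a functional assay on HCT-116 cells (Homo sapiens) for cytotoxicity (a lower number here means a stronger inhibitor, a higher number a weaker inhibitor), compound 1 gives 79000 nM, while compound 2 gives 19000 nM. Among the measured compounds shown here, the single measured step, a 4.2-fold lower number from compound 1 to compound 2 (0.62 log units; beyond the scatter), separates the two. Compound 2 therefore stands as the lower of the two numbers, with compound 1 as its only comparator.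

Compound 3, `COc1ccc(C2=C(c3ccsc3)C(=O)N3CCCC3C2)cc1`, is not yet measured. It differs from compound 2 in one place: thiophen-3-yl in place of pyridin-4-yl on a double-bonded ring carbon. For the measured compounds named here, no measured step involves a thiophene, and the one step available, a 4.2-fold lower number from compound 1 to compound 2 (0.62 log units; beyond the scatter), concerns only the position of the nitrogen within a pyridine ring on the same carbon. It shows that the aryl group at this position matters at the modest level, but gives no direction for the present change. The expectation is a step of at most modest size, with no firm direction, as a 1.3-fold higher number from compound 2 to compound 3 (0.12 log units; within the scatter). Compound 3 is estimated at 25000 nM, with a range from 6000 nM to 100000 nM.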

Compound 3, half-maximal inhibitory concentration: 1500 nM
The estimate for compound 3 lay 17-fold (1.22 log units) above the measured number; measured number below the stated range.
By their numbers in this assay, from the lowest: compound 3; then compound 2; then compound 1.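

In this assay, the group on the double-bonded ring carbon carries more weight than the two pyridines suggested: a 13-fold lower number from compound 2 to compound 3 (1.10 log units; beyond the scatter) is a large step and a 53-fold lower number from compound 1 to compound 3 (1.72 log units; beyond the scatter) is larger still, whereas a 4.2-fold lower number from compound 1 to compound 2 (0.62 log units; beyond the scatter) stays modest. Replacing either six-membered pyridine ring with the five-membered thiophen-3-yl ring therefore moves the number further than the change of pyridine attachment does, even though the counts of hydrogen-bond donors and acceptors stay the same. No supporting measurement bears on why this exchange has so large an effect.

The compounds shown leave open whether the gain belongs to thiophene as such, since a plain phenyl ring, a furan-3-yl ring or thiophen-2-yl at this carbon could fall near compound 3 or near the pyridines. They also leave open whether the thiophen-3-yl gain would persist if the 4-methoxyphenyl group on the neighbouring ring atom gave way to a 4-hydroxyphenyl or 4-fluorophenyl group.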